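Swapping the alkyne-capped ring: thiophene to pyridine

This account rests on a few compounds, and the source may have more. Where it says the series, first, only, none or still open, it means among the compounds named here.

Measured compounds:
compound 1 `CN(C)S(=O)(=O)c1cncc(C#Cc2cc(Cl)ccc2OCC(=O)O)c1` with 37 nM
compound 2 `CS(=O)(=O)c1cncc(C#Cc2cc(Cl)ccc2OCC(=O)O)c1` with 60 nM
compound 3 `O=C(O)COc1ccc(Cl)cc1C#Cc1ccc(Cl)s1` with 183 nM

In an assay on CHO cells for displacement of a labelled ligand from prostaglandin D2 receptor 2 (Homo sapiens), read by scintillation counting (a lower number here means a stronger inhibitor, a higher number a weaker inhibitor), compound 3 gives the highest of the three numbers, and both of its gaps to the others lie beyond the scatter. Compound 1 and compound 2 differ only in the group on the sulfonyl sulfur, and a 1.6-fold higher number from compound 1 to compound 2 (0.21 log units; within the scatter) shows that this change stays within the scatter. Within the data shown here, compound 3 differs from those two in more than one place, so no single step connects it to them; its value and that of compound 2 simply show that the thiophene-bearing compound sits higher.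

Compound 4 `O=C(O)COc1ccc(Cl)cc1C#Cc1cccnc1` is obtained from compound 3 by the change (pyridin-3-yl in place of 5-chlorothiophen-2-yl on a triple-bonded carbon). Among the measured compounds shown here, no measured step touches this kind of swap: the one measured step concerns a substituent on a pyridine ring that compound 4 lacks, and compound 1 and compound 2 both carry a sulfonyl group on their pyridine that compound 4 does not. The expectation therefore rests on little, and the estimated step is a 1.2-fold lower number from compound 3 to compound 4 (0.09 log units; within the scatter), that is, no step beyond the scatter, with a wide margin either way. Compound 4 is thus estimated at 150 nM, with a range from 45 nM to 500 nM.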

Compound 4, inhibition constant: 117 nM
Compound 4: middle estimate off by 1.3-fold (0.11 log units), on the high side, within the range that was stated.
By their numbers in this assay, from the lowest: compounds 1, 2, 4 and 3 (each within the scatter of the next, the first and the last beyond it).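

In this assay, pyridin-3-yl in place of 5-chlorothiophen-2-yl on the triple-bonded carbon gives a 1.6-fold lower number from compound 3 to compound 4 (0.19 log units; within the scatter) and so stays within the scatter, which shows that this position takes either the five-membered or the six-membered aromatic ring without a clear shift in the number. The unsubstituted pyridin-3-yl compound also links the thiophene compound to the sulfonyl-bearing pair: hydrogen in place of methylsulfonyl gives a 2.0-fold higher number from compound 2 to compound 4 (0.29 log units; within the scatter) and remains within the scatter, while hydrogen in place of dimethylsulfamoyl gives a 3.2-fold higher number from compound 1 to compound 4 (0.50 log units; beyond the scatter) and is a modest step beyond it, the only one of the three new steps to be so. Nothing available here gives a reason for any of these steps.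

The compounds shown leave open whether methylsulfonyl or dimethylsulfamoyl would give a similar step on the 5-chlorothiophen-2-yl ring. They also leave open how a phenyl ring at the same place, or an amino group or a carboxamide on the pyridin-3-yl ring, would compare with these compounds.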